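A few compounds are considered here, and "the series" means these few. Any claim that something is new, unique, unknown or untested is made for them only; others in the source may bear on it.

In an ADME assay on Vero cells (Chlorocebus sabaeus) for cytotoxicity, read by fluorescence and resazurin assay, with a stated time of 3 days (on this read-out higher numbers stand for lower toxicity in this test and lower numbers for higher toxicity in this test), compound 1 (`COC(=O)C[C@H]([C@H]1O[C@@H]2OC(C)(C)O[C@@H]2[C@H]1OCc1ccccc1)n1cnc2c(N)ncnc21`) gives 86300 nM as its half-maximal cytotoxic concentration. Compound 2 (`CC1(C)O[C@H]2O[C@H]([C@H](CCO)n3cnc4c(N)ncnc43)[C@H](OCc3ccccc3)[C@H]2O1`) gives 97100 nM in this assay and so stands level with compound 1, the two values lying within the scatter of repeated measurements.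

Compound 3 (`COC(=O)C[C@@H]([C@H]1O[C@@H]2OC(C)(C)O[C@@H]2[C@H]1OCc1ccccc1)n1cnc2c(N)ncnc21`) has not yet been measured. Its structure departs from that of compound 2 by methoxycarbonyl in place of hydroxymethyl on a saturated chain carbon, two bonds along the chain from an aromatic nitrogen and a saturated ring carbon.

Among the measured compounds shown here, no measured pair differing in one place is available to size this change, so the expectation rests on the two values alone. Compound 1 at 86300 nM and compound 2 at 97100 nM show no gap beyond the scatter, and no step beyond the scatter is expected in this assay in either direction. The expected step is a 1.1-fold lower number from compound 2 to compound 3 (0.06 log units; within the scatter) and lies within the scatter. In this assay compound 3 is expected at 85000 nM (estimated range 45000 nM to 130000 nM).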

Compound 3, half-maximal cytotoxic concentration: 68400 nM
Compound 3: middle estimate off by 1.2-fold (0.09 log units), on the high side, within the range that was stated.
By their numbers in this assay, from the lowest: compounds 3, 1 and 2 (each within the scatter of the next).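

Among the compounds shown here, the compounds now give a first direct reading of the stereocentre at this saturated chain carbon: in this assay, the change of configuration alone comes to a 1.3-fold lower number from compound 1 to compound 3 (0.10 log units; within the scatter), which lies within the scatter. The exchange of hydroxymethyl for methoxycarbonyl on the same carbon comes to a 1.4-fold lower number from compound 2 to compound 3 (0.15 log units; within the scatter), also within the scatter, so neither change separates its two compounds in this test. The first of these comparisons speaks to configuration and nothing else, because the two structures hold no other difference: the fact that compounds 1 and 3 differ only in the configuration as drawn.

As far as these compounds go, it remains open whether a carboxylic acid, an amine or a longer chain in this place would stay level with these compounds, since only 2-hydroxyethyl and (methoxycarbonyl)methyl are represented here. For the compounds shown here, it is also open whether configuration at this carbon would count for as little with 2-hydroxyethyl on the chain, since the comparison of configurations rests on the single pair carrying (methoxycarbonyl)methyl, and these values speak only to this assay.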